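The source may report more compounds than this note shows. Statements on the series, on what has been measured and on what is new or still open speak of the compounds shown alone.

Compound 2 `Cn1ncc(Cl)c1-c1cc(C(=O)N[C@@H]2CN[C@H](CC(=O)O)C[C@H]2c2ccc(Cl)c(Cl)c2)oc1Cl` gives 5120 nM in a functional assay on OVCAR-8 cells (Homo sapiens) for antiproliferative activity (on this read-out lower numbers stand for stronger inhibition and higher numbers for weaker inhibition), the highest of the two numbers at hand, while compound 1 `Cn1ncc(Cl)c1-c1cc(C(=O)N[C@@H]2CN[C@H](CC(=O)NC3CC3)C[C@H]2c2ccc(Cl)c(Cl)c2)oc1Cl` gives 580 nM. Within the data shown here, the single measured step, an 8.8-fold higher number from compound 1 to compound 2 (0.95 log units; beyond the scatter), shows that the carboxy end of compound 2 goes with the weaker result. Compound 3 `C=CC[C@@H]1C[C@@H](c2ccc(Cl)c(Cl)c2)[C@H](NC(=O)c2cc(-c3c(Cl)cnn3C)c(Cl)o2)CN1` differs from compound 2 by vinyl in place of carboxy on a saturated chain carbon bound to a saturated ring carbon. Among the measured compounds shown here, no measured pair covers this exact change, so the expectation leans only on compound 2 standing weakest. A lower number than compound 2 is expected, though short of compound 1. Compound 3 is estimated at 1500 nM, within 500 nM to 4500 nM. That amounts to an expected 3.4-fold lower number from compound 2 to compound 3 (0.53 log units; beyond the scatter).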

Compound 3, half-maximal inhibitory concentration: 990 nM
The estimate for compound 3 lay 1.5-fold (0.18 log units) above the measured number, and the stated range covers the measured number.
By their numbers in this assay, from the lowest: compounds 1 and 3 (each within the scatter of the next); then compound 2.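

In this assay, allyl in place of carboxymethyl gives a 5.2-fold lower number from compound 2 to compound 3 (0.71 log units; beyond the scatter), so moving away from the weak result of compound 2 does not require an amide at this place. With a 1.7-fold higher number from compound 1 to compound 3 (0.23 log units; within the scatter), compound 3, whose vinyl end has no hydrogen-bond donor or acceptor, cannot be told apart from compound 1, which carries the cyclopropylcarbamoyl group. No measurement at hand gives a reason for either step. On these data alone, whether a primary amine or a longer saturated chain such as butyl would fit this pattern remains open.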